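The compounds below may be only part of what the source reports. "The series", "measured", "known", "first", "only" and "open" are said of these compounds alone.

Working notes on the bis-enone series.

Compound 1 `COc1ccc(/C=C/C(=O)c2c(C)cc(O)c(C(=O)/C=C/c3ccc(OC)c(OC)c3)c2-c2ccccc2)cc1OC` is the reference point. In an ADME assay on HEK293 cells (Homo sapiens) for cytotoxicity, read by MTT assay, with a stated time of 24 h (on this read-out lower numbers stand for stronger inhibition and higher numbers for weaker inhibition), compound 1 gives "not active" (no number reported), so no number stands against it, only a report of no activity. Two other members of the series have been run. Compound 2 `Cc1cc(O)c(C(=O)/C=C/c2ccc(F)cc2)c(-c2ccc(OCc3ccccc3)cc2)c1C(=O)/C=C/c1ccc(F)cc1`, which carries a benzyloxy group on its pendant aryl ring, gives 30000 nM in this assay, a weak but numbered result. Compound 3 `Cc1cc(O)c(C(=O)/C=C/c2ccc3ccccc3c2)c(-c2ccccc2)c1C(=O)/C=C/c1ccc2ccccc2c1` gives "not active" (no number reported) in this assay, again with no number reported. The series as seen so far is therefore either inactive or only weakly cytotoxic toward these cells.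

Compound 4 `COc1ccc(/C=C/C(=O)c2c(C)cc(O)c(C(=O)/C=C/c3ccc(OC)c(OC)c3)c2-c2ccc(OCc3ccccc3)cc2)cc1OC` has not yet been measured. Against compound 1 the change is benzyloxy in place of hydrogen on an aromatic carbon. For the measured compounds named here, the same benzyloxy substituent is present in compound 2, the one compound of the three that returned a number, while compound 1 and compound 3 both lack it. Going by the values given here, no measured pair isolates this single change, so the size of the step cannot be taken from the data. The expectation is that compound 4 lands in the weak region occupied by compound 2, with a real chance that the assay again reports no activity rather than a number.

Compound 4 is estimated at 40000 nM in this assay, expected to fall between 15000 nM and 150000 nM.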

Compound 4, half-maximal inhibitory concentration: 30000 nM
Beside the measured number, compound 4's estimate is 1.3-fold (0.12 log units) above it, within the range that was stated.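

For the compounds shown here, no step from compound 1 to compound 4 can be read: in this assay compound 1 gives "not active" (no number reported) and so has no number to set against the value of compound 4. The compounds shown leave open how large the effect of benzyloxy alone is on this read-out. No data bearing on a cause are available.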